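A few compounds are considered here, and "the series" means these few. Any claim that something is new, unique, unknown or untested is made for them only; others in the source may bear on it.

In a functional assay on SGC-7901 cells (Homo sapiens) for inhibition, read by MTT assay, with a stated time of 72 h (a lower number here means a stronger inhibitor, a higher number a weaker inhibitor), compound 1 `O=C(NCc1ccc(NC(=O)c2cc(-c3ccccc3)ccc2N2CCCC2)cc1)OCc1cccnc1` reaches only a limit, > 100000 nM. Going by the values given here, compound 2 `COc1ccc(N2CCCC2)c(C(=O)Nc2ccc(CNC(=O)OCc3cccnc3)cc2)c1` gives 47200 nM, the only actual number so far. Compound 3 `O=C(NCc1ccc(NC(=O)c2cc(Cl)ccc2N2CCCC2)cc1)OCc1cccnc1` remains unmeasured. It carries chloro in place of methoxy on an aromatic carbon, meta to a large group and para to a pyrrolidin-1-yl group: chloro in place of methoxy on an aromatic carbon. Among the compounds with values here, one measured step bears on this change, an at least 2.1-fold lower number from compound 1 to compound 2 (0.32 log units; beyond the scatter), which puts methoxy in place of phenyl at that place. Within the data shown here, its size is known from one side only, as the limit of > 100000 nM in this assay, at which 1 of the 2 values shown sits, shows, and no measured step involves chloro. Among the measured compounds shown here, from the single step of an at least 2.1-fold lower number from compound 1 to compound 2 (0.32 log units; beyond the scatter), no change beyond the scatter is expected in this assay, in either direction. The estimate means an expected 1.0-fold lower number from compound 2 to compound 3 (0.02 log units; within the scatter). For compound 3 the estimated value is 45000 nM, with an expected range of 15000 nM to 100000 nM.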

Compound 3, half-maximal inhibitory concentration: > 100000 nM
Compound 3: only a limit was reported; the forecaster's own chance of this, stated with the estimate: 25%; at least 2.2-fold (0.34 log units) between middle value and limit.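

At this position, para to a pyrrolidin-1-yl group, the result shows that methoxy cannot be replaced by chloro without loss in this assay: chloro in place of methoxy gives an at least 2.1-fold higher number from compound 2 to compound 3 (0.32 log units; beyond the scatter). Going by these compounds alone, until now, the only measured change here was the one from phenyl to methoxy, so methoxy now stands apart from two different groups, phenyl and chloro, neither of which gives an actual number. The step from compound 1 to compound 3 cannot be read, since both values are limits: the limit of > 100000 nM in this assay, at which 2 of the 3 values shown sit.

From the compounds shown here alone, what remains open is whether any other group at this place, such as an amine, a hydroxyl or the longer ethoxy, would match or better compound 2. With a single actual number in the series, the compounds shown also leave open how far phenyl and chloro differ from each other.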